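Furan-2-yl to 2-fluorophenyl on the shared core

The source may report more compounds than this note shows. Statements on the series, on what has been measured and on what is new or still open speak of the compounds shown alone.

Measured so far:
compound 1, `c1ccc(N2N=C(c3ccc4c(c3)OCCO4)CC2c2ccco2)cc1`: > 100000 nM
compound 2, `c1ccc(COc2cccc(C3CC(c4ccc5c(c4)OCCO5)=NN3c3ccccc3)c2)cc1`: 870 nM

The read-out throughout is a functional assay on WM 266-4 cells (Homo sapiens) for antiproliferative activity, read by MTT assay, with a stated time of 24 h; on this read-out higher numbers stand for weaker inhibition of growth and lower numbers for stronger inhibition of growth. For compound 1 the value > 100000 nM is a limit of the assay, not a number; it stands at the limit of > 100000 nM in this assay, at which 1 of the 2 values shown sits. Compound 2 gives 870 nM in this assay, a measured number. Among the measured compounds shown here, no step between compound 1 and compound 2 is counted here; their two values show only that compound 1 sits at the limit while compound 2 gives a number well inside the measured range.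

Compound 3, `Fc1ccccc1C1CC(c2ccc3c(c2)OCCO3)=NN1c1ccccc1`, is not yet measured. From compound 1 it differs by 2-fluorophenyl in place of furan-2-yl on a saturated ring carbon. For the measured compounds named here, because compound 1 stands only at a limit, no measured step can anchor the size of the change. The expectation leans on compound 2, which gives 870 nM in this assay and shows that the shared core can reach measurable inhibition. Compound 3 is expected to move toward stronger inhibition, with the step of an at least 5.0-fold lower number from compound 1 to compound 3 (0.69 log units; beyond the scatter) expected to carry it below the limit. In this assay compound 3 is estimated at 20000 nM, with a range from 3000 nM to 100000 nM.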

Compound 3, concentration for 50% growth inhibition: 9120 nM
Compound 3: middle estimate off by 2.2-fold (0.34 log units), on the high side; the measured number falls inside the stated range.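

In this assay, 2-fluorophenyl in place of furan-2-yl on a saturated ring carbon gives an at least 10-fold lower number from compound 1 to compound 3 (1.04 log units; beyond the scatter), so on the shared core the group at this one position is enough to separate a limit from a measured number. Compound 1 gives > 100000 nM, which is a limit of the assay and not a number. The step therefore sets only a lower bound on the size of this change, and its true size remains unknown, because one end of it rests on that limit: the limit of > 100000 nM in this assay, at which 1 of the 3 values shown sits.

The compounds shown leave open whether the change in this assay follows from the six-membered aromatic ring of carbon or from the fluorine it carries, a question that plain phenyl at this position would address. They also leave open whether a five-membered aromatic ring as such goes with the weak end of the read-out, or whether this holds only for furan-2-yl, which thiophen-2-yl at the same saturated ring carbon would help to settle.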